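This account rests on a few compounds, and the source may have more. Where it says the series, first, only, none or still open, it means among the compounds named here.

Compound 1 `COc1cc(NC(=O)Nc2cc(Nc3ccc(OC)c(C)c3)ncn2)cc(OC)c1` has the lower of the two measured numbers: in a functional assay on NCI-H520 cells (Homo sapiens) for inhibition, read by MTT assay, with a stated time of 48 h, tested at 10 uM (on this read-out higher numbers stand for more inhibition at the one concentration tested (going by the name of the read-out) and lower numbers for less inhibition), compound 1 gives 13.5%, while compound 2 `Cc1ccc(Nc2cc(NC(=O)Nc3c(Cl)cccc3Cl)ncn2)cc1F` gives 33.5%, a gap beyond the usual scatter. Compound 3 `COc1cc(NC(=O)Nc2cc(Nc3ccc(C)c(F)c3)ncn2)cc(OC)c1` differs from compound 1 in one place: 3-fluoro-4-methylphenyl in place of 4-methoxy-3-methylphenyl on a nitrogen on an aromatic ring. Among the measured compounds shown here, no single-change step among measured compounds shows what such a swap does, so only a small upward step a number 11.5 percentage points higher from compound 1 to compound 3 (beyond the scatter) is expected, leaning upward since compound 2 gives 33.5%. For compound 3 the estimate in this assay is 25%, within 8% to 45%.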

Compound 3, a percentage reported as inhibition, at one concentration (the size of the read-out at that concentration, not a potency): 30.6%
For compound 3 the middle estimate is 5.6 percentage points below the measured one, within the range that was stated.
By their numbers in this assay, from the lowest: compound 1; then compounds 3 and 2 (each within the scatter of the next).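

In this assay, putting 3-fluoro-4-methylphenyl in place of 4-methoxy-3-methylphenyl on this nitrogen gives a number 17.1 percentage points higher from compound 1 to compound 3 (beyond the scatter). This single change shows that the group at this position can alter the inhibition seen at the one concentration tested, even with the rest of compound 1 unchanged. Nothing available explains the rise.

Methoxy leaves and fluorine enters in the same swap, so their separate contributions remain open. Also open, as far as these compounds go, is what an amine or a carboxylic acid on this phenyl ring would do.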